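Swapping the amide aryl group on a fluorinated flavonol core

The source may hold more compounds than are shown below. What is called first, only, known or untested is meant among the compounds shown, and "the series" means these compounds.

Of the compounds shown here, two sharing one core have been tested in a functional assay on HeLa cells (Homo sapiens) for antiproliferative activity, read by CCK-8 assay, with a stated time of 72 h; on this read-out higher numbers stand for weaker inhibition and lower numbers for stronger inhibition. Compound 1 `COc1ccccc1C(=O)Nc1cccc(-c2oc3cc(-c4ccc(F)cc4)ccc3c(=O)c2O)c1` gives 14100 nM in this assay. Compound 2 `O=C(Nc1cccc(-c2oc3cc(-c4ccc(F)cc4)ccc3c(=O)c2O)c1)c1cccc(F)c1` gives 8780 nM in this assay. Going by the values given here, the only step between them, a 1.6-fold lower number from compound 1 to compound 2 (0.21 log units; within the scatter), changes the aryl group attached to the carbonyl carbon, and it stays within the scatter, so compound 2 and compound 1 cannot be told apart on these numbers. Compound 3 `Cc1cc(C)cc(C(=O)Nc2cccc(-c3oc4cc(-c5ccc(F)cc5)ccc4c(=O)c3O)c2)c1` follows the same idea: 3,5-dimethylphenyl in place of 3-fluorophenyl on a carbonyl carbon. Among the compounds with values here, the one measured step that bears on it, a 1.6-fold lower number from compound 1 to compound 2 (0.21 log units; within the scatter), varied exactly this group and produced nothing beyond the scatter, and no other information about this position exists. Compound 3 is therefore expected to stay close to compound 2, with an estimated step of a 1.1-fold lower number from compound 2 to compound 3 (0.04 log units; within the scatter). The estimate for compound 3 in this assay is 8000 nM, with a range from 3000 nM to 22000 nM.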

Compound 3, half-maximal inhibitory concentration: 5540 nM
For compound 3 the middle estimate is 1.4-fold (0.16 log units) above the measured one; low and high end bracket the measured number.
By their numbers in this assay, from the lowest: compounds 3, 2 and 1 (each within the scatter of the next, the first and the last beyond it).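

In this assay the step of a 1.6-fold lower number from compound 2 to compound 3 (0.20 log units; within the scatter) is again small, so 3,5-dimethylphenyl and 3-fluorophenyl on this carbonyl carbon cannot be told apart. Going by these compounds alone, the new information comes from the wider comparison, a 2.5-fold lower number from compound 1 to compound 3 (0.41 log units; beyond the scatter), which is the first step at this position to clear the scatter: replacing 2-methoxyphenyl with 3,5-dimethylphenyl gives a modest gain in inhibition, so the aryl group here can influence the read-out. Nothing available explains this difference.

The compounds shown all carry a substituted phenyl ring at this position, so it remains open how a pyridine ring or a cyclohexyl group would behave in its place. On these data alone, the effect of a dimethylamino group or a carboxylic acid on the phenyl ring also remains open.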